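The source may hold more compounds than are shown below. What is called first, only, known or untested is meant among the compounds shown, and "the series" means these compounds.

Measured in a functional assay on A549 cells (Homo sapiens) for inhibition, read by sulforhodamine B assay, with a stated time of 72 h; on this read-out higher numbers stand for weaker inhibition of growth and lower numbers for stronger inhibition of growth:
compound 1 `NNC(=O)CCc1ccncc1-c1ccc2ccccc2c1`: > 10000 nM (a limit)
compound 2 `O=C(CCc1ccncc1-c1ccc2ccccc2c1)N1CCOCC1`: > 10000 nM (a limit)

Compound 1 has no numerical value on this read-out, only the limit > 10000 nM. Compound 2 likewise gives only a limit, > 10000 nM. The evidence so far is therefore (the limit of > 10000 nM in this assay, at which 2 of the 2 values shown sit).

Compound 3 `COC(=O)/C=C/c1ccncc1-c1ccc2ccccc2c1` has not yet been measured. Its difference from compound 1 is 2-(methoxycarbonyl)ethenyl in place of 2-(aminocarbamoyl)ethyl on an aromatic carbon. In short, 2-(methoxycarbonyl)ethenyl stands in place of 2-(aminocarbamoyl)ethyl on an aromatic carbon, ortho to a large group and opposite the ring nitrogen.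

Going by the values given here, the only measured step bearing on this change is a step that the two limits leave unreadable from compound 1 to compound 2. It concerns a different change and offers no size to carry over, so no step beyond the scatter can be derived from it, in either direction. The working expectation is that compound 3 stays close to the limit in this assay, and a limit alone may well be reported. The expected step is a step that the limit leaves unreadable from compound 1 to compound 3, an estimate that remains loose. For compound 3 the estimated value is 12000 nM, with an expected range of 4000 nM to 30000 nM.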

Compound 3, concentration for 50% growth inhibition: 760 nM
Beside the measured number, compound 3's estimate is 16-fold (1.20 log units) above it; the measured number lies below the stated range.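

In this assay, replacing 2-(aminocarbamoyl)ethyl with 2-(methoxycarbonyl)ethenyl gives an at least 13-fold lower number from compound 1 to compound 3 (1.11 log units; beyond the scatter), showing that the substituent at this position, ortho to a large group and opposite the ring nitrogen, can decide whether the shared core gives a measurable value at all. The earlier pair could not show this: the step between compound 1 and compound 2 cannot be read, and that change lay at the far end of the carbonyl group, leaving the chain itself untouched. Compound 3 is now the only compound shown with a number on this read-out, and its step is a lower bound on the true size of the change, with the rest of the evidence consisting of limits: the limit of > 10000 nM in this assay, at which 2 of the 3 values shown sit.

The change replaces the end group and adds a chain double bond in a single step, and the compounds shown do not separate these two parts or say which of them carries the gain. Going by these compounds, a 2-(methoxycarbonyl)ethyl group would test the double bond alone, while a carboxylic acid or a primary amide on the ethenyl chain would test the methyl ester, and both questions remain open.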